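This account rests on a few compounds, and the source may have more. Where it says the series, first, only, none or still open, it means among the compounds named here.

Compound 1 `Cc1ccc(Nc2nc(SCc3cn(CC(=O)NC(=O)Nc4ccccn4)nn3)nc(-c3ccc(C(C)C)cc3)c2C#N)cc1`; compound 2 `Cc1ccc(Nc2nc(SCc3cn(CC(=O)NC(=O)Nc4ccccn4)nn3)nc(-c3ccc(C)cc3)c2C#N)cc1`; compound 3 `Cc1ccc(Nc2nc(SCc3cn(CC(=O)NC(=O)Nc4ccccn4)nn3)nc(-c3ccc(Br)cc3)c2C#N)cc1`, not yet measured.

In a functional assay on ECa-109 cells (Homo sapiens) for inhibition, read by MTT assay, with a stated time of 72 h (on this read-out lower numbers stand for stronger inhibition and higher numbers for weaker inhibition), compound 1 gives 6700 nM. Going by these compounds, compound 2 gives only a limit, > 64000 nM, so its true number is unknown. Compound 2 thus stands at the limit of > 64000 nM in this assay, at which 1 of the 2 values shown sits, the weak end of what is shown. The change to compound 3 is bromo in place of methyl on an aromatic carbon. The only measured step, an at least 9.5-fold higher number from compound 1 to compound 2 (0.98 log units; beyond the scatter), swaps two alkyl groups and does not involve a bromo, so no shown step bears directly on this change. The step is estimated as an at least 1.6-fold lower number from compound 2 to compound 3 (0.20 log units; that floor lies within the scatter), with a real chance that compound 3 again yields only a limit. Compound 3 is expected near 40000 nM, between 10000 nM and 130000 nM.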

Compound 3, half-maximal inhibitory concentration: 7920 nM
Estimate against measurement, compound 3: 5.1-fold (0.70 log units) above; measured number below the stated range.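

In this assay, the weak result with methyl proves not to need an alkyl group to be undone: bromo on the same aromatic carbon gives an at least 8.0-fold lower number from compound 2 to compound 3 (0.90 log units; beyond the scatter). That step is only a floor, as one end of it is a limit: the limit of > 64000 nM in this assay, at which 1 of the 3 values shown sits. Bromo also sits level with isopropyl, at a 1.2-fold higher number from compound 1 to compound 3 (0.07 log units; within the scatter), so a branched alkyl group is not required at this position.

Going by these compounds, whether chloro, methoxy or an amine here would behave like bromo or like methyl stays open. For the compounds shown here, with only three groups compared, what separates methyl from the other two cannot be said.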